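This account rests on a few compounds, and the source may have more. Where it says the series, first, only, none or still open, it means among the compounds named here.

Compound 1 `Nc1ccccc1NC(=O)c1ccc(CSC(=S)N2CCN(c3ccc(Cl)cc3)CC2)cc1` carries a dithiocarbamate linked through a piperazine to a 4-chlorophenyl group. In a functional assay on MGC-803 cells (Homo sapiens) for antiproliferative activity, read by CCK-8 assay, with a stated time of 72 h, tested at 8 uM (on this read-out higher numbers stand for a stronger effect at the one concentration tested and lower numbers for a weaker effect), compound 1 gives 17.2%. Its companion in this series, compound 2 `Nc1ccccc1NC(=O)c1ccc(CSC(=S)N2CCc3cc(Cl)ccc32)cc1`, replaces the piperazine unit with a chlorinated bicyclic amine, and in this assay compound 2 gives 82.2%. Going by the values given here, of the two numbers known so far, compound 1 has the lower one, and the gap to compound 2 is far wider than the usual scatter of repeated measurements.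

The next compound, compound 3 `Nc1ccccc1NC(=O)c1ccc(CSC(=S)N2CCN(C3CCCCC3)CC2)cc1`, keeps the whole of compound 1 except for one group: cyclohexyl in place of 4-chlorophenyl on an amine nitrogen in a ring. Among the compounds with values here, no measured pair here shows what such a swap does, so the expected size of the step rests only on what compound 1 and compound 2 show. Compound 3 is expected to move only modestly upward from compound 1, a step of a number 9.8 percentage points higher from compound 1 to compound 3 (within the scatter), which may well fall within the scatter. On that basis compound 3 is estimated at 27% in this assay, within a range from 6% to 58%.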

Compound 3, a percentage reported as inhibition, at one concentration (the size of the read-out at that concentration, not a potency): 75.3%
Compound 3: middle estimate off by 48.3 percentage points, on the low side, and the stated range ends below it.
By their numbers in this assay, from the lowest: compound 1; then compounds 3 and 2 (each within the scatter of the next).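

In this assay, the group on an amine nitrogen in a ring proves decisive: with the rest of compound 1 kept intact, cyclohexyl in place of 4-chlorophenyl gives a step of a number 58.1 percentage points higher from compound 1 to compound 3 (beyond the scatter) at the one concentration tested. Going by these compounds alone, this is the first comparison that changes a single place, and it shows that the six-membered non-aromatic ring with 2 nitrogen does not by itself fix the read-out at a low level, as compound 3 keeps that ring and gives 75.3%. The swap removes both the aromatic ring and the chlorine, and no measurement available here explains the size of the step or separates the contributions of those two features.

The compounds shown leave open whether the chlorine or the aromatic ring accounts for the step, a question that a plain phenyl group on the same nitrogen would help to settle. They also leave open how far the result extends to other groups at this position, such as a cyclopentyl ring, an n-butyl chain or a tetrahydropyranyl ring.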